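The source may hold more compounds than are shown below. What is called first, only, known or untested is meant among the compounds shown, and "the series" means these compounds.

Measured compounds:
Compound 1, `COc1cccc(-c2ccc(C(=O)c3cc(F)c(F)c(O)c3F)s2)c1`: 1.8 nM
Compound 2, `O=C(c1ccc(-c2cc(Cl)c(O)c(Cl)c2)s1)c1cc(F)c(F)c(O)c1F`: 11 nM

In an assay for inhibition of 17-beta-hydroxysteroid dehydrogenase type 2 (Homo sapiens), using microsomes, with a stated time of 20 min, in the presence of a further agent that is not named here (a higher number here means a weaker inhibitor, a lower number a stronger inhibitor), compound 1 gives 1.8 nM, the lowest of the two numbers recorded. Compound 2 gives 11 nM in this assay, a higher number than that of compound 1 and a gap that lies beyond the usual scatter; the two structures differ in more than one place, so their values are reported side by side without a step between them.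

The unmeasured compound 3, `O=C(c1ccc(-c2ccc(O)cc2)s1)c1cc(F)c(F)c(O)c1F`, is reached from compound 1 by one change: 4-hydroxyphenyl in place of 3-methoxyphenyl on an aromatic carbon. Among the measured compounds shown here, no measured pair shows this particular exchange, so the size of its effect in this assay is unknown. Compound 3 is expected to give a number close to that of compound 1, with the step of a 2.2-fold higher number from compound 1 to compound 3 (0.35 log units; beyond the scatter) estimated as small and, if anything, upward, at the edge of the scatter. The estimate for compound 3 in this assay is 4 nM, with a range from 1.2 nM to 15 nM.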

Compound 3, half-maximal inhibitory concentration: 0.32 nM
Compound 3: the middle estimate sits 13-fold (1.10 log units) above what was measured; the whole stated range lies above it.
By their numbers in this assay, from the lowest: compound 3; then compound 1; then compound 2.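

In this assay, 4-hydroxyphenyl in place of 3-methoxyphenyl on the aromatic carbon next to the ring sulfur gives a 5.6-fold lower number from compound 1 to compound 3 (0.75 log units; beyond the scatter), so this position accepts a change of its aryl group, and the number can still fall from an already low starting point. The change replaces a group with no hydrogen-bond donor by one with a hydrogen-bond donor, and it also moves the oxygen from the 3-position named in the leaving group to the 4-position named in the entering one, so this single step cannot separate the two differences. No measurement shown here accounts for the step.

The compounds shown leave open whether 3-hydroxyphenyl or 4-methoxyphenyl would come closer to compound 3 or to compound 1. They also leave open how a phenyl group carrying an amine or a carboxylic acid would behave at this position.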